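The compounds below may be only part of what the source reports. "The series", "measured", "known", "first", "only" and "open" are said of these compounds alone.

Compound 1 `CC(C)=CC(=O)Nc1cccc(Oc2nc(Nc3ccn(C)n3)nc3c2CSCC3)c1` is the starting point of this series. In an ADME assay on L02 cells (Homo sapiens) for cytotoxicity, read by MTT assay, with a stated time of 72 h (on this read-out higher numbers stand for weaker inhibition and lower numbers for stronger inhibition), compound 1 gives > 50000 nM, which is a limit of the assay and not a number. Compound 2 `CC(C)/C=C/C(=O)Nc1cccc(Oc2nc(Nc3ccn(C)n3)nc3c2CSCC3)c1` differs from compound 1 only by 3-methylbut-1-en-1-yl in place of 2-methylprop-1-en-1-yl on a carbonyl carbon. In this assay compound 2 gives > 50000 nM, again a limit rather than a number. The resulting step is a step that the two limits leave unreadable from compound 1 to compound 2. Compound 3 `COc1ccc(Nc2nc3c(c(Oc4cccc(NC(=O)C=C(C)C)c4)n2)CSCC3)cn1` carries a different core, the difference being (6-methoxypyridin-3-yl in place of 1-methyl-1H-pyrazol-3-yl on a nitrogen on an aromatic ring). In this assay compound 3 gives > 50000 nM, once more a limit. The step from the core of compound 1 to the core of compound 3 is a step that the two limits leave unreadable from compound 1 to compound 3. All three measured compounds therefore share one position, namely (the limit of > 50000 nM in this assay, at which 3 of the 3 values shown sit), so none of them can be ordered against the others.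

Compound 4 `COc1ccc(Nc2nc3c(c(Oc4cccc(NC(=O)/C=C/C(C)C)c4)n2)CSCC3)cn1` is not yet measured. It is related to compound 3 by 3-methylbut-1-en-1-yl in place of 2-methylprop-1-en-1-yl on a carbonyl carbon, and the place of this change reads word for word as it does for the change from compound 1 to compound 2, so it is the same change made on the core of compound 3 rather than on the core of compound 1. Because the step from compound 1 to compound 2 stays at the limit of > 50000 nM in this assay, at which 3 of the 3 values shown sit, for both compounds, and compound 3 sits at the same limit, compound 4 is expected to give a step that the limit leaves unreadable from compound 3 to compound 4 in this assay, with a high likelihood that only a limit is reported again. Compound 4 is therefore estimated at 70000 nM in this assay, with an expected range from 30000 nM to 200000 nM.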

Compound 4, half-maximal inhibitory concentration: > 50000 nM
Compound 4 was reported as a limit (the forecaster's own chance of this, stated with the estimate: 85%); the middle value does not contradict the limit.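

In this assay, compound 4 sits at a limit and not at a number, like compound 2 and compound 3, so no step can be read from compound 3 to compound 4 or from compound 2 to compound 4: the limit of > 50000 nM in this assay, at which 4 of the 4 values shown sit. The compounds shown leave open whether either of the two changes has any effect on this read-out, and how the four compounds order against one another.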